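The compounds below may be only part of what the source reports. "The series", "measured", "known", "first", "only" and "open" are said of these compounds alone.

Among the measured compounds shown here, compound 2 `CC1CCN(C2CCN(S(=O)(=O)c3ccc(-c4ccc(Cl)cc4)cc3)CC2)CC1` gives 105 nM in a functional assay on DLD-1 cells (Homo sapiens) for antiproliferative activity, read by CellTiter-Glo, with a stated time of 72 h (a higher number here means a weaker inhibitor, a lower number a stronger inhibitor), the higher of the two numbers so far; compound 1 `COc1ccccc1-c1ccc(S(=O)(=O)N2CCC(N3CCC(C)CC3)CC2)cc1` gives 26 nM in this assay. For the measured compounds named here, the only measured step, a 4.0-fold higher number from compound 1 to compound 2 (0.61 log units; beyond the scatter), swaps one aromatic substituent for another. Compound 3 `CC1CCN(C2CCN(S(=O)(=O)c3ccc(C(C)C)cc3)CC2)CC1` instead carries isopropyl in place of 4-chlorophenyl on an aromatic carbon. Going by the values given here, no measured step removes the ring itself, so that step is only a loose guide. For compound 3 a modest rise is expected, estimated as 400 nM with a range of 100 nM to 2000 nM, which would mean a 3.8-fold higher number from compound 2 to compound 3 (0.58 log units; beyond the scatter).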

Compound 3, half-maximal inhibitory concentration: 685 nM
Estimate against measurement, compound 3: 1.7-fold (0.23 log units) below; the measured number falls inside the stated range.
By their numbers in this assay, from the lowest: compound 1; then compound 2; then compound 3.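

Putting isopropyl, which has no ring, in place of the aryl group on this aromatic carbon weakens the compound in this assay, with a 6.5-fold higher number from compound 2 to compound 3 (0.81 log units; beyond the scatter) and a 26-fold higher number from compound 1 to compound 3 (1.42 log units; beyond the scatter). Compound 3 is therefore the weakest of the three, and the two compounds that keep an aromatic ring at this position both give lower numbers. Nothing available explains this loss of activity. The compounds shown cannot separate the loss of the ring from the loss of size, since only one ring-free group appears. From the compounds shown here alone, how a longer chain, an amine or a carboxylic acid would behave here remains open.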